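The compounds below may be only part of what the source reports. "The series", "measured", "known", "first", "only" and "open" are said of these compounds alone.

Series notes. In a functional assay on MDA-MB-231 cells (Homo sapiens) for cytotoxicity, read by MTT assay, with a stated time of 48 h (a higher number here means that more compound is needed for the effect, a lower number that less compound is needed), compound 1 `CO[C@H]1O[C@H](COc2ccc3c(c2)CCCC3)[C@@H](O)[C@H](O)[C@H]1Oc1ccc(OC2CCCCC2)cc1` gives 20000 nM, and compound 3 `CO[C@H]1O[C@H](COc2ccc(OC3CCCCC3)cc2)[C@@H](O)[C@H](O)[C@H]1Oc1ccc(OC2CCCCC2)cc1` gives 20000 nM; these two values lie within the scatter of each other. In this assay compound 2 `CO[C@@H]1O[C@H](COc2ccc3c(c2)CCCC3)[C@@H](O)[C@H](O)[C@H]1Oc1ccc(OC2CCCCC2)cc1` gives "not determined" (no result reported), so no number fixes where it stands; the nearest anchor is the fact that compounds 1 and 2 differ only in the configuration as drawn, which places compound 1 beside it. Compound 4 `CO[C@@H]1O[C@H](COc2ccccc2C(C)C)[C@@H](O)[C@H](O)[C@H]1Oc1ccc(OC2CCCCC2)cc1` differs from compound 2 by 2-isopropylphenyl in place of 1,2,3,4-tetrahydronaphthalen-6-yl on an oxygen on a saturated carbon. Going by the values given here, no measured pair shows a change of this kind, so the size of the step in this assay is not constrained by the data; with both measured neighbours at the same level, no shift beyond the scatter is expected in either direction. Compound 4 is therefore expected to give about 20000 nM in this assay, within a range of 8000 nM to 50000 nM.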

Compound 4, half-maximal effective concentration: 44000 nM
Estimate against measurement, compound 4: 2.2-fold (0.34 log units) below, within the range that was stated.
By their numbers in this assay, from the lowest: compounds 1 and 3 (each within the scatter of the next); then compound 4.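

No new step can be read for compound 4, since its single-change neighbour, compound 2, has no number in this assay. Open remain the effect of 2-isopropylphenyl in place of 1,2,3,4-tetrahydronaphthalen-6-yl and that of the configuration as drawn.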